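Fluorine Returns on the Shared Core at a New Position

A few compounds are considered here, and "the series" means these few. Any claim that something is new, unique, unknown or untested is made for them only; others in the source may bear on it.

Compound 1 `Fc1ccc(-c2cn3ccnc3c(-c3ccc4ncn(C5CCCCC5)c4c3)n2)cc1`: 53.6%
Compound 2 `c1cn2cc(-c3ccsc3)nc(-c3ccc4ncn(C5CCCCC5)c4c3)c2n1`: 19.9%
Compound 3 `Brc1ccc(-c2cn3ccnc3c(-c3ccc4ncn(C5CCCCC5)c4c3)n2)cc1`: 42.4%

In a functional assay on PC-3 cells (Homo sapiens) for inhibition, read by sulforhodamine B assay, with a stated time of 48 h, tested at 10 uM (on this read-out higher numbers stand for more inhibition at the one concentration tested (going by the name of the read-out) and lower numbers for less inhibition), compound 3 gives 42.4% and stands second highest of the three numbers; the nearest measured step is a number 11.2 percentage points lower from compound 1 to compound 3 (beyond the scatter) and the furthest is a number 22.5 percentage points higher from compound 2 to compound 3 (beyond the scatter). Compound 4 `Fc1ccccc1-c1cn2ccnc2c(-c2ccc3ncn(C4CCCCC4)c3c2)n1` differs from compound 3 in one place: 2-fluorophenyl in place of 4-bromophenyl on an aromatic carbon. The step that bears on this is a number 11.2 percentage points lower from compound 1 to compound 3 (beyond the scatter), a modest loss on going from fluoro to bromo, so reversing that exchange suggests a modest gain. Going by the values given here, no measured step, however, moves a halogen from one ring position to another, so that part of the change is untested. The step is therefore expected to be a number 5.6 percentage points higher from compound 3 to compound 4 (within the scatter), a small rise that may still lie within the scatter. Compound 4 is estimated at 48%, between 30% and 65%.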

Compound 4, a percentage reported as inhibition, at one concentration (the size of the read-out at that concentration, not a potency): 32.6%
For compound 4 the middle estimate is 15.4 percentage points above the measured one, and the stated range covers the measured number.
By their numbers in this assay, from the lowest: compound 2; then compounds 4 and 3 (each within the scatter of the next); then compound 1.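

Going by these compounds alone, with fluorine kept and only its ring position changed, the switch from 4-fluorophenyl to 2-fluorophenyl gives a number 21 percentage points lower from compound 1 to compound 4 (beyond the scatter) and shows for the first time that placement on this ring counts at this site. Against 4-bromophenyl, the 2-fluorophenyl group gives a number 9.8 percentage points lower from compound 3 to compound 4 (within the scatter) and so is not separated from it, while against thiophen-3-yl it gives a number 12.7 percentage points higher from compound 2 to compound 4 (beyond the scatter) and stays clearly ahead. As far as these compounds go, whether a methoxy group or an amine on the phenyl ring would match the halogens remains open. No measurement shown accounts for these steps.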